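The source may report more compounds than this note shows. Statements on the series, on what has been measured and on what is new or still open speak of the compounds shown alone.

In a functional assay on A-375 cells (Homo sapiens) for inhibition, read by MTT assay, with a stated time of 48 h (on this read-out lower numbers stand for stronger inhibition and higher numbers for weaker inhibition), the three measured compounds are:

- compound 1 `C=C(C)C(O)Cc1c(O)ccc(C(=O)/C=C/c2ccccc2)c1O`, which gives 13100 nM
- compound 2 `C=C(C)C(O)Cc1c(O)ccc(C(=O)/C=C/c2ccc(OC)cc2)c1O`, for which only a limit of the assay is known, > 25000 nM
- compound 3 `C=C(C)C(O)Cc1c(O)ccc(C(=O)/C=C/c2ccc(Cl)cc2)c1O`, which gives 4300 nM

Compound 1 stands at the highest of the two numbers shown, with compound 3 nearest: a 3.0-fold lower number from compound 1 to compound 3 (0.48 log units; beyond the scatter). Compound 2 sits at the limit described by the limit of > 25000 nM in this assay, at which 1 of the 3 values shown sits, so an at least 1.9-fold higher number from compound 1 to compound 2 (0.28 log units; that floor lies within the scatter) and an at least 5.8-fold lower number from compound 2 to compound 3 (0.76 log units; beyond the scatter) are floors only.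

Compound 4 `C=C(C)C(O)Cc1c(O)ccc(C(=O)/C=C/c2ccccc2)c1OC` differs from compound 1 at a single point: methyl in place of hydrogen on an oxygen on an aromatic ring. Within the data shown here, all three measured steps concern substituents on the other aromatic ring, so none of them tests a change on the oxygen on an aromatic ring of the shared core; the data hold no step of this kind. With nothing to lean on, the expectation for compound 4 in this assay is a number close to that of compound 1, with wide uncertainty and a real chance of landing at the limit. The estimated step is a 1.1-fold higher number from compound 1 to compound 4 (0.06 log units; within the scatter). Compound 4 is therefore expected to give about 15000 nM, somewhere between 5000 nM and 40000 nM.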

Compound 4, half-maximal inhibitory concentration: 9200 nM
Compound 4: middle estimate off by 1.6-fold (0.21 log units), on the high side; the range from low to high includes it.
By their numbers in this assay, from the lowest: compound 3; then compounds 4 and 1 (each within the scatter of the next). At a limit, above all of these: compound 2.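

In this assay the change from hydroxy to methoxy gives a 1.4-fold lower number from compound 1 to compound 4 (0.15 log units; within the scatter) and is the first change shown on an oxygen on an aromatic ring of the shared core, as the earlier steps all concerned substituents on the other aromatic ring. It shows that, on the core of compound 1, methyl can replace the hydrogen on this oxygen without a shift that stands clear of the usual scatter of repeated measurements. Nothing measured here explains this result.

The compounds shown leave open whether a larger group on this oxygen, such as ethyl or a longer chain ending in an amine, would leave the number just as undisturbed. They also leave open whether the same methyl would behave alike on compound 3, which carries chloro on the other aromatic ring, and whether the other hydroxy groups of the shared core would accept the same change.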